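This account rests on a few compounds, and the source may have more. Where it says the series, first, only, none or still open, it means among the compounds named here.

Working notes on a small series of azetidinyl- and pyrrolidinyl-methoxy pyridines. The series is read in an assay on membranes from brain with Neuronal acetylcholine receptor; alpha4/beta2 (Rattus norvegicus) as the target; a higher number here means a weaker inhibitor, a lower number a stronger inhibitor. Compound 1, `Clc1ncc(OC[C@@H]2CCCN2)cc1-c1cccnc1`, gives 0.021 nM in this assay. Compound 2, `Clc1ccc(-c2cc(OC[C@@H]3CCN3)cnc2Cl)cn1`, gives 0.0045 nM. Compound 3, `Fc1cc(-c2cc(OC[C@@H]3CCN3)cnc2Cl)ccn1`, gives 0.0048 nM.

Compound 3 sits close to compound 2; the two values lie within the usual scatter, so no order between them can be read. Against compound 1 the number for compound 3 is clearly lower, a gap beyond the scatter, so compound 3 counts as a stronger inhibitor than compound 1.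

Compound 4, `Clc1ncc(OC[C@@H]2CCN2)cc1-c1ccnc(Br)c1`, is not yet measured in this assay. It differs from compound 3 in one place: bromo in place of fluoro on an aromatic carbon, on an aromatic carbon of a six-membered aromatic ring with one nitrogen, next to the ring nitrogen. Among the compounds with values here, no measured pair carries this exchange, so the direction cannot be anchored on data. A step of a 1.7-fold higher number from compound 3 to compound 4 (0.22 log units; within the scatter) is expected, not beyond the scatter. Compound 4 is estimated at 0.008 nM, with a range from 0.003 nM to 0.02 nM.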

Compound 4, inhibition constant: 0.0033 nM
Estimate against measurement, compound 4: 2.4-fold (0.38 log units) above, and the stated range covers the measured number.
By their numbers in this assay, from the lowest: compounds 4, 2 and 3 (each within the scatter of the next); then compound 1.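

In this assay, bromo in place of fluoro on the aromatic carbon next to the ring nitrogen gives a 1.5-fold lower number from compound 3 to compound 4 (0.16 log units; within the scatter). Within the data shown here, this is the first pair that differs in one place, and it shows that, at this position, this exchange of one halogen for the other leaves the number within the scatter. No measurement at hand bears on why the two halogens read alike.

The compounds shown leave open whether an amine, a methoxy group or a nitrile on this same carbon would read like the two halogens, or whether the plain hydrogen would. They also leave open what the side chain on the core contributes, since compound 1 differs from the other compounds in more than one place and gives no clean comparison.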